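Swapping One Aryl Group in a Small Cell-Growth Series

A few compounds are considered here, and "the series" means these few. Any claim that something is new, unique, unknown or untested is made for them only; others in the source may bear on it.

Of the compounds shown here, three built on one shared core have been tested in a functional assay on MCF7 cells (Homo sapiens) for inhibition, read by sulforhodamine B assay, with a stated time of 72 h; on this read-out higher numbers stand for weaker inhibition and lower numbers for stronger inhibition. Compound 1 `Cc1ccc(C2=Nn3c(nnc3C(C)c3ccc(CC(C)C)cc3)SC2)cc1` gives 6300 nM. Compound 2 `CC(c1ccc(-c2ccccc2)c(F)c1)c1nnc2n1N=C(c1ccc(Cl)cc1Cl)CS2` gives 7600 nM, and compound 3 `COc1ccc2cc(C(C)c3nnc4n3N=C(c3ccc(F)cc3)CS4)ccc2c1` gives 15800 nM. On these three numbers compound 2 holds the second highest place: its nearest neighbour is compound 1, whose number sits lower by an amount within the usual scatter, so the two cannot be told apart, while compound 3 sits further off with a higher number, a gap that lies beyond the scatter.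

Compound 4 `CC(c1ccc(-c2ccccc2)c(F)c1)c1nnc2n1N=C(c1ccc(C(F)(F)F)cc1)CS2` has not yet been measured. It differs from compound 2 in one place only: 4-(trifluoromethyl)phenyl in place of 2,4-dichlorophenyl on a carbon with a double bond to nitrogen. Within the data shown here, no measured pair in this set shows what such a swap does on this core, so the expectation can rest only on the three known numbers, which all fall in the same broad region. The expected change is small, likely within the scatter, with a slight lean toward a higher number: a 1.2-fold higher number from compound 2 to compound 4 (0.07 log units; within the scatter). Compound 4 is therefore estimated at 9000 nM in this assay, with a range from 3500 nM to 25000 nM.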

Compound 4, half-maximal inhibitory concentration: 4300 nM
For compound 4 the middle estimate is 2.1-fold (0.32 log units) above the measured one; low and high end bracket the measured number.
By their numbers in this assay, from the lowest: compounds 4, 1 and 2 (each within the scatter of the next); then compound 3.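

In this assay, this position now has its first comparison in which nothing else on the shared core differs: with 4-(trifluoromethyl)phenyl in place of 2,4-dichlorophenyl on a carbon with a double bond to nitrogen, the result is a 1.8-fold lower number from compound 2 to compound 4 (0.25 log units; within the scatter). Although the two groups differ in their atoms and in their substitution, the read-out cannot tell compound 2 and compound 4 apart, so this exchange gives no detectable effect in this one pair, and the difference between their numbers should not be read as a real gain. No measurement is available here that could explain why the exchange leaves the result inside the scatter.

The compounds shown leave open whether this position would accept something of a different kind, such as a phenyl ring carrying an amine or a carboxylic acid, or a plain alkyl chain in place of the aromatic ring. They also leave open whether the same exchange would behave alike with the other groups carried by compound 1 and compound 3, since each of those differs from compound 2 in more than one place.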